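The compounds below may be only part of what the source reports. "The series", "measured", "known", "first", "only" and "open" are said of these compounds alone.

Compound 3 `CC1CCN(C(=O)N2CC(c3nc(-c4cccc(Cl)c4)no3)C2)CC1` is the point of departure. In an assay on HEK293 cells for negative allosteric modulation of metabotropic glutamate receptor 5 (Homo sapiens), read by FLIPR (on this read-out lower numbers stand for stronger inhibition and higher numbers for weaker inhibition), compound 3 gives only a limit, > 10000 nM. Compound 1 `O=C(N1CCC(F)CC1)N1CC(c2nc(-c3cccc(Cl)c3)no2)C1` likewise reaches only a limit in this assay, > 10000 nM. Compound 2 `CC1CCC(C(=O)N2CC(c3nc(-c4cccc(Cl)c4)no3)C2)CC1` also stops at a limit in this assay, > 10000 nM. As a result the three measured steps, a step that the two limits leave unreadable from compound 1 to compound 2, a step that the two limits leave unreadable from compound 1 to compound 3 and a step that the two limits leave unreadable from compound 2 to compound 3, cannot be sized: the limit of > 10000 nM in this assay, at which 3 of the 3 values shown sit. Compound 4 `COC1CCCN(C(=O)N2CC(c3nc(-c4cccc(Cl)c4)no3)C2)C1` differs from compound 3 in one place: 3-methoxypiperidin-1-yl in place of 4-methylpiperidin-1-yl on a carbonyl carbon. Among the measured compounds shown here, none of the measured steps involves a 3-methoxypiperidin-1-yl group, and the two steps that touch compound 3 are both unreadable, so they give no direction for this assay. With every measured neighbour of compound 4 sitting at the same limit, the expected outcome is that compound 4 also lands at the limit, and no step beyond the scatter can be foreseen in either direction. The estimate for compound 4 is therefore 15000 nM, within 4000 nM to 60000 nM. The expected step that the limit leaves unreadable from compound 3 to compound 4 is thus small.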

Compound 4, half-maximal inhibitory concentration: 1830 nM
For compound 4 the middle estimate is 8.2-fold (0.91 log units) above the measured one; the measured number lies below the stated range.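

On the carbonyl carbon, 3-methoxypiperidin-1-yl in place of 4-methylpiperidin-1-yl gives the first readable result at this position in this assay, an at least 5.4-fold lower number from compound 3 to compound 4 (0.73 log units; beyond the scatter). The same group gives an at least 5.4-fold lower number from compound 1 to compound 4 (0.73 log units; beyond the scatter) in place of 4-fluoropiperidin-1-yl and an at least 5.4-fold lower number from compound 2 to compound 4 (0.73 log units; beyond the scatter) in place of 4-methylcyclohexyl, so a change at this position can bring the read-out off the limit, and each of these sizes is only a minimum. The steps among the other three compounds still cannot be read: the limit of > 10000 nM in this assay, at which 3 of the 4 values shown sit.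

The compounds shown leave open whether the methoxy group itself matters or its place on the ring. 4-Methoxypiperidin-1-yl, 3-hydroxypiperidin-1-yl or morpholin-4-yl on the same carbonyl carbon would be needed to tell these apart.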